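A Carbamoyl Returns in Place of Fluorine

The source may hold more compounds than are shown below. What is called first, only, known or untested is meant among the compounds shown, and "the series" means these compounds.

Measured compounds:
- compound 1 `CCC1C(=O)N(C)c2cnc(-n3ccc4cc(C(=O)NCC(C)C)ccc43)nc2N1c1ccn(C)n1`: 10200 nM
- compound 2 `CCC1C(=O)N(C)c2cnc(-n3ccc4cc(F)ccc43)nc2N1c1ccn(C)n1`: 28600 nM

In a functional assay on NCI-H1975 cells (Homo sapiens) for antiproliferative activity, read by CCK-8 assay, with a stated time of 72 h (a lower number here means a stronger inhibitor of growth, a higher number a weaker inhibitor of growth), compound 2 gives 28600 nM, the highest of the two numbers shown, so it is the weaker inhibitor of growth of the pair. Its nearest neighbour is compound 1, which gives 10200 nM in this assay. Among the measured compounds shown here, the only step measured is the one from compound 1 to compound 2, a 2.8-fold higher number from compound 1 to compound 2 (0.45 log units; beyond the scatter), in which fluoro took the place of isobutylcarbamoyl on an aromatic carbon.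

Compound 3 `CCCNC(=O)c1ccc2c(ccn2-c2ncc3c(n2)N(c2ccn(C)n2)C(CC)C(=O)N3C)c1` is not yet measured. It differs from compound 2 as follows: propylcarbamoyl in place of fluoro on an aromatic carbon. This change brings a carbamoyl group back onto the same aromatic carbon, with a propyl chain instead of the isobutyl chain of compound 1. The measured step bears directly on it, since it runs the same exchange the other way; because that step was a 2.8-fold higher number from compound 1 to compound 2 (0.45 log units; beyond the scatter), a decrease of about the same size is expected here, giving an expected step of a 2.6-fold lower number from compound 2 to compound 3 (0.41 log units; beyond the scatter). Compound 3 is therefore estimated to give 11000 nM in this assay, within a range of 5000 nM to 25000 nM.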

Compound 3, concentration for 50% growth inhibition: 11000 nM
Compound 3: the middle estimate sits on the measured number at the digits printed; the range from low to high includes it.
By their numbers in this assay, from the lowest: compounds 1 and 3 (each within the scatter of the next); then compound 2.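

In this assay, propylcarbamoyl in place of fluoro gives a 2.6-fold lower number from compound 2 to compound 3 (0.41 log units; beyond the scatter), so the advantage of compound 1 over the fluoro compound is not confined to the isobutyl amide: a second carbamoyl group on the same aromatic carbon also stands apart from fluoro. Comparing the two amides, the hydrogen in place of methyl on a saturated chain carbon gives a 1.1-fold higher number from compound 1 to compound 3 (0.03 log units; within the scatter), so this assay does not distinguish the propyl chain from the isobutyl chain. Nothing available explains either step in terms of how these groups act on the cells.

The two amides leave open whether the carbamoyl group itself or the chain on it is what counts, a question that a carbamoyl group with no chain, a longer chain such as hexyl, or a chain ending in an amine or a carboxylic acid could help to settle. Also open, as far as these compounds go, is whether any group on this aromatic carbon can bring the number much lower than that of compound 3, at 11000 nM.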